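Nitro removal on the oxadiazole series, liver cell toxicity

The compounds below may be only part of what the source reports. "The series", "measured", "known", "first", "only" and "open" are said of these compounds alone.

Measured so far:
compound 1 `CC(=O)OC[C@H]1O[C@H](OC[C@@H](Cn2cc(CN(c3nc(-c4ccc([N+](=O)[O-])cc4)no3)C3CCCCC3)nn2)OC(C)=O)C=C[C@@H]1OC(C)=O` – > 200 ug/mL
compound 2 `CC(=O)OC[C@H]1O[C@H](OC[C@H](Cn2cc(-c3ccc(-c4noc(NC5CCCCC5)n4)cc3)nn2)OC(C)=O)C=C[C@@H]1OC(C)=O` – 79.8 ug/mL

In an ADME assay on HepG2 cells (Homo sapiens) for cytotoxicity, read by MTT assay, with a stated time of 48 h (on this read-out lower numbers stand for higher toxicity in this test and higher numbers for lower toxicity in this test), compound 1 gives > 200 ug/mL, which is a limit of the assay and not a number. Compound 2 gives 79.8 ug/mL in this assay. Going by the values given here, no step connects these two compounds. Compound 1 stands at the limit, as the limit of > 200 ug/mL in this assay, at which 1 of the 2 values shown sits, shows. Compound 3 `CC(=O)OC[C@H]1O[C@H](OC[C@@H](Cn2cc(CN(c3nc(-c4ccccc4)no3)C3CCCCC3)nn2)OC(C)=O)C=C[C@@H]1OC(C)=O` differs from compound 1 by hydrogen in place of nitro on an aromatic carbon. Among the compounds with values here, no comparable step is on hand; the step from compound 1 to compound 3 is expected to stay within the scatter, an at least 1.1-fold lower number from compound 1 to compound 3 (0.04 log units; that floor lies within the scatter), with a fair chance that only a limit is reported again. For compound 3 a value of 180 ug/mL is estimated, between 70 ug/mL and 400 ug/mL.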

Compound 3, half-maximal cytotoxic concentration: 19.9 ug/mL
Estimate against measurement, compound 3: 9.0-fold (0.96 log units) above; measured number below the stated range.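

At the 4-nitrophenyl position, the group is not a silent passenger in this assay: hydrogen in place of nitro gives an at least 10-fold lower number from compound 1 to compound 3 (1.00 log units; beyond the scatter). Going by these compounds alone, the earlier compounds offered no step at this place, so this is the first sign that toxicity in this test depends on it. The size is only a floor, since compound 1 stands at a limit: the limit of > 200 ug/mL in this assay, at which 1 of the 3 values shown sits.

As far as these compounds go, whether an amine or a methoxy group at this place would stay nearer compound 1 or compound 3 remains open. Compound 2 differs in more than one place and settles nothing here.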